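A few compounds are considered here, and "the series" means these few. Any claim that something is new, unique, unknown or untested is made for them only; others in the source may bear on it.

In an ADME assay on microsomes from liver (Rattus norvegicus) for metabolic stability (on this read-out higher numbers stand for a longer-lived compound and lower numbers for a shorter-lived compound), compound 1 `CCn1ncc2c(F)cc(-c3ccc(C(CC)(CC)c4nnc[nH]4)c(=O)[nH]3)cc21` sits at > 3 h, which is a limit of the assay rather than a number. Compound 2 `CCC(CC)(c1nnc[nH]1)c1ccc(-c2ccc3cccc(F)c3c2)[nH]c1=O` gives 0.925 h in this assay. Compound 3 `CC(C)C(c1nnc[nH]1)c1ccc(-c2ccc3cccc(F)c3c2)[nH]c1=O` gives 0.552 h in this assay, the lower of the two numbers, though its gap to compound 2 lies within the scatter and the two cannot be told apart. Compound 4 `CC(C)NC(=O)CC(c1ccc(-c2ccc3cccc(F)c3c2)[nH]c1=O)C(C)C` has not yet been measured in this assay. It differs from compound 3 in one place: (isopropylcarbamoyl)methyl in place of 4H-1,2,4-triazol-3-yl on a saturated chain carbon bound to an aromatic carbon and a saturated chain carbon. For the measured compounds named here, no measured pair isolates this change, so in this assay a step of a 1.1-fold lower number from compound 3 to compound 4 (0.04 log units; within the scatter) is expected, within the scatter and with no clear direction. Compound 4 is therefore expected to give about 0.5 h, in a range from 0.2 h to 1.3 h.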

Compound 4, half-life: < 0.0667 h
Compound 4 gave a limit, no number (the forecaster's own chance of this, stated with the estimate: 5%); middle value at least 7.4-fold (0.87 log units) away from the limit.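

In this assay, the group on this saturated chain carbon matters: (isopropylcarbamoyl)methyl in place of 4H-1,2,4-triazol-3-yl gives an at least 8.2-fold lower number from compound 3 to compound 4 (0.91 log units; beyond the scatter). The earlier compounds shown here all carry 4H-1,2,4-triazol-3-yl here, so they could not show this. For compound 4 the reading is a limit of the assay, not a number, so the full size of the step stays unknown: the limit of < 0.0667 h in this assay, at which 1 of the 4 values shown sits.

The compounds shown leave open whether the step comes from losing 4H-1,2,4-triazol-3-yl or from gaining (isopropylcarbamoyl)methyl, and how a carboxylic acid or a simple amine would fare at this place.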